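This account rests on a few compounds, and the source may have more. Where it says the series, first, only, none or still open, it means among the compounds named here.

For the measured compounds named here, in a functional assay (aorta) with Rattus norvegicus as the target (a lower number here means that less compound is needed, a higher number that more compound is needed for the effect), compound 2 `CNC1=NS(=O)(=O)c2cc(Cl)ccc2N1` gives 142 uM, the only exact number available so far. Compound 1 `CNC1=NS(=O)(=O)c2cc(F)ccc2N1` gives > 300 uM, and this is a limit of the assay rather than a number. Going by the values given here, the one measured change, chloro in place of fluoro on an aromatic carbon, is an at least 2.1-fold lower number from compound 1 to compound 2 (0.32 log units; beyond the scatter).

Compound 3 `CC(C)C(C)NC1=NS(=O)(=O)c2cc(Cl)ccc2N1` keeps the chloro of compound 2 but changes another part of the molecule, with 1,2-dimethylpropyl in place of methyl on an amine nitrogen. Among the compounds with values here, no measured step touches that amine nitrogen. The step of an at least 2.1-fold lower number from compound 1 to compound 2 (0.32 log units; beyond the scatter) therefore shows only that this assay can respond to a single change, and its size cannot simply be carried over. Even so, the swap is much larger than a single exchange of one atom, and compound 2 at 142 uM leaves plenty of room for a lower number.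

A move beyond the scatter towards less compound needed is expected, estimated as a 7.1-fold lower number from compound 2 to compound 3 (0.85 log units; beyond the scatter). For compound 3, the expected value is 20 uM, with an estimated range of 4 uM to 90 uM.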

Compound 3, concentration for half-maximal effect: 1.2 uM
Estimate against measurement, compound 3: 17-fold (1.22 log units) above; the whole stated range lies above it.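

Replacing methyl with 1,2-dimethylpropyl on the amine nitrogen gives a 120-fold lower number from compound 2 to compound 3 (2.07 log units; beyond the scatter) in this assay, so this nitrogen is a place where a single change moves the result strongly, and the larger carbon group is compatible with the effect. Both ends of this step are exact numbers, so its size can be read directly. The earlier step from the fluoro to the chloro compound can give only a minimum size, as its starting point, compound 1, is a limit of the assay rather than a number: the limit of > 300 uM in this assay, at which 1 of the 3 values shown sits.

This one pair cannot separate the effect of the number of carbons from that of the branched shape, and groups such as ethyl, a straight pentyl chain or a cyclohexyl ring on the same nitrogen would help to tell these apart. As far as these compounds go, it also remains open whether the gain depends on the chloro group, since 1,2-dimethylpropyl appears here only with chloro and not with fluoro or a group such as bromo on the aromatic carbon.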